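Phenoxy in place of 2-methylphenyl on the shared core

The source may report more compounds than this note shows. Statements on the series, on what has been measured and on what is new or still open speak of the compounds shown alone.

Three analogues of one core have been run. Compound 1 `c1ccc(-c2nn3c(-c4ccncc4)nnc3s2)cc1` gives 66.4% in a functional assay on the whole organism for inhibition, with Rattus norvegicus as the target, read by paw edema, with a stated time of 4 h, at a dose of 70 mg/kg by the oral route; a lower number here means less inhibition, a higher number more inhibition at the dose given (going by the name of the read-out). Compound 2 `Cc1ccccc1-c1nn2c(-c3ccncc3)nnc2s1` gives 79.8% in this assay and stands highest of the three numbers, separated from both others beyond the scatter. Compound 3 `CC(=O)Oc1ccccc1-c1nn2c(-c3ccncc3)nnc2s1` gives 39.8% in this assay. The steps are a number 13.4 percentage points higher from compound 1 to compound 2 (beyond the scatter), a number 26.6 percentage points lower from compound 1 to compound 3 (beyond the scatter) and a number 40 percentage points lower from compound 2 to compound 3 (beyond the scatter).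

Compound 4 `c1ccc(Oc2nn3c(-c4ccncc4)nnc3s2)cc1` awaits measurement. The change from compound 2 is phenoxy in place of 2-methylphenyl on an aromatic carbon. Going by the values given here, the only measured change that brings in an oxygen-bearing group with a hydrogen-bond acceptor is the one to compound 3, where the step was a number 40 percentage points lower from compound 2 to compound 3 (beyond the scatter), large and downward. A downward step is therefore expected for compound 4, though its phenyl ring is kept, so a smaller drop is estimated: a number 27.8 percentage points lower from compound 2 to compound 4 (beyond the scatter). Compound 4 is expected to give about 52% in this assay, within 32% to 70%.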

Compound 4, a percentage reported as inhibition, in the whole organism at one dose (the size of the read-out at that dose, not a potency): 63.6%
The estimate for compound 4 lay 11.6 percentage points below the measured number; measured number inside the range.
By their numbers in this assay, from the lowest: compound 3; then compounds 4 and 1 (each within the scatter of the next); then compound 2.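

In this assay, phenoxy and phenyl on this aromatic carbon of the shared core cannot be told apart (a number 2.8 percentage points lower from compound 1 to compound 4 (within the scatter)). Phenoxy does not keep the number reached with 2-methylphenyl (a number 16.2 percentage points lower from compound 2 to compound 4 (beyond the scatter)), so at this position phenoxy stands with phenyl rather than with 2-methylphenyl. Nothing available accounts for either step. Open, from the compounds shown here alone, is whether an amine or a carboxylic acid on the phenyl ring of phenoxy would shift the number in this assay, and whether a longer chain in place of phenoxy would do so.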